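Swapping methoxy for chloro in a pair of pyrimidine-free words

A few compounds are considered here, and "the series" means these few. Any claim that something is new, unique, unknown or untested is made for them only; others in the source may bear on it.

Measured compounds:
Compound 1, `COc1ccc(Cl)cc1-c1cc(Nc2ccc(Cl)cc2)nc(N)n1`, gives 54 nM in an assay on Sf9 cells for inhibition of 1-acyl-sn-glycerol-3-phosphate acyltransferase beta (Homo sapiens); a lower number here means a stronger inhibitor, a higher number a weaker inhibitor.
Compound 2, `CCOc1ccc(Br)cc1-c1cc(Nc2ccc(/C(C)=N\O)cc2)nc(N)n1`, gives 84 nM in this assay.

Only these two compounds have been measured. The number for compound 1 and the number for compound 2 lie within the usual scatter of repeated measurements of each other, so neither can be called the stronger or the weaker inhibitor on this evidence; the two share a common core and differ at several places at once, so no single structural change can be read from them.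

Compound 3, `Nc1nc(Nc2ccc(Cl)cc2)cc(-c2cc(Cl)ccc2Cl)n1`, has not yet been measured. It differs from compound 1 in one place: chloro in place of methoxy on an aromatic carbon. Among the measured compounds shown here, no measured pair shows what such a change does in this assay, so the size and direction of the step are unknown. Because compound 1 already gives 54 nM, and a single small substituent swap is expected to move the number by no more than a modest amount, the estimated step of a 1.4-fold higher number from compound 1 to compound 3 (0.14 log units; within the scatter) is expected to stay within or only slightly beyond the scatter. Compound 3 is therefore expected to give about 75 nM, with a range from 25 nM to 220 nM.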

Compound 3, half-maximal inhibitory concentration: 20 nM
The estimate for compound 3 lay 3.8-fold (0.57 log units) above the measured number; the whole stated range lies above it.
By their numbers in this assay, from the lowest: compound 3; then compounds 1 and 2 (each within the scatter of the next).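

This pair is the first among the compounds shown to differ in one place only, so it gives the first direct reading of this position, on an aromatic carbon ortho to a large group and para to a chloro group. In this assay, chloro in place of methoxy gives a 2.7-fold lower number from compound 1 to compound 3 (0.43 log units; beyond the scatter), a modest step but one beyond the scatter, showing that methoxy is not required here for a low number and that chloro, with 1 heavy atom and 0 hydrogen-bond acceptors against 2 heavy atoms and 1 hydrogen-bond acceptor for methoxy, does better on this core. Nothing measured alongside this pair explains the drop, so it stands as an observation without a known cause.

Going by these compounds, it remains open whether the same swap would give a step of similar size and direction with other groups elsewhere on the shared core, as this is a single pair. On these data alone, it also remains open how an amine, a hydroxyl, a trifluoromethyl or a longer chain such as propoxy would compare with chloro at this position.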